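Oxime to benzoyl swap: estimate for compound 4

The source may hold more compounds than are shown below. What is called first, only, known or untested is meant among the compounds shown, and "the series" means these compounds.

Measured so far:
compound 1 `C=CCn1c(SC/C(=N/O)c2ccccc2)nnc1-c1ccc(OC)cc1`, 57%
compound 2 `C=CCn1c(SCC(=O)c2ccccc2)nnc1-c1ccc(OC)cc1`, 61%
compound 3 `CCn1c(SC/C(=N/O)c2ccccc2)nnc1-c1ccc(OC)c(OC)c1`, 71%

All numbers come from a functional assay on the whole organism (strain albino) for inhibition, with Rattus norvegicus as the target, read by paw edema, with a stated time of 5 h, at a dose of 0.28 mmol/kg by the oral route; a lower number here means less inhibition, a higher number more inhibition at the dose given (going by the name of the read-out). Compound 2 differs from compound 1 by a group of 8 heavy atoms (7 carbon, 1 oxygen; one six-membered aromatic ring of carbon only) in place of a group of 9 heavy atoms (7 carbon, 1 nitrogen, 1 oxygen; one six-membered aromatic ring of carbon only), on a saturated chain carbon bound to a sulfur; the step is a number 4 percentage points higher from compound 1 to compound 2 (within the scatter). Compound 3 stands beyond the scatter above compound 1, while its gap to compound 2 is within the scatter. The difference between the core of compound 1 and the core of compound 3 is not broken down here.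

Compound 4 `CCn1c(SCC(=O)c2ccccc2)nnc1-c1ccc(OC)c(OC)c1` is not yet measured. It differs from compound 3 by a group of 8 heavy atoms (7 carbon, 1 oxygen; one six-membered aromatic ring of carbon only) in place of a group of 9 heavy atoms (7 carbon, 1 nitrogen, 1 oxygen; one six-membered aromatic ring of carbon only), on a saturated chain carbon bound to a sulfur, the same change as that between compound 1 and compound 2, at the same place. Because a number 4 percentage points higher from compound 1 to compound 2 (within the scatter) was small, the expected step is a number 3 percentage points higher from compound 3 to compound 4 (within the scatter). For compound 4 the estimate in this assay is 74%, with a range expected from 62% to 84%.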

Compound 4, a percentage reported as inhibition, in the whole organism at one dose (the size of the read-out at that dose, not a potency): 69%
Compound 4: middle estimate off by 5 percentage points, on the high side, within the range that was stated.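

In this assay, the swap to benzoyl on a saturated chain carbon bound to a sulfur gives a number 2 percentage points lower from compound 3 to compound 4 (within the scatter). Set beside the earlier step, the same change on the two cores does not differ: the same change on two cores in this assay, a number 4 percentage points higher (within the scatter) from compound 1 to compound 2 and a number 2 percentage points lower (within the scatter) from compound 3 to compound 4, 6 percentage points apart, within the scatter of two such steps. On these two cores the swap therefore leaves the inhibition within the scatter, but this does not show that the step is truly zero, and two pairs do not show that it would carry over to any further core.

Still open, going by these compounds, is what an amine or a carboxylic acid would give in place of benzoyl at this place. The core of compound 1 and the core of compound 3 also differ in a way these pairs do not break down.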